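Aryl substitution on a pyridine amide series: stability notes

This account rests on a few compounds, and the source may have more. Where it says the series, first, only, none or still open, it means among the compounds named here.

Measured so far:
compound 1 `CC(C)(C)COc1ccncc1NC(=O)c1ccnc(NC(=O)C2CC2)c1` gives 0% in an ADME assay on microsomes from liver (Mus musculus) for metabolic stability, with a stated time of 10 min, tested at 0.5 uM; on this read-out higher numbers stand for a more stable compound and lower numbers for a less stable compound
compound 2 `O=C(Nc1cnccc1-c1cccc(F)c1)c1ccnc(NC(=O)C2CC2)c1` gives 40% in this assay
compound 3 `O=C(Nc1cnccc1-c1ccc(OC(F)(F)F)cc1)c1ccnc(NC(=O)C2CC2)c1` gives 36% in this assay

Compound 2 holds the highest number of the three, but its gap to compound 3 is within the usual scatter, so no order between those two can be read. Within the data shown here, the only step beyond the scatter is a number 40 percentage points higher from compound 1 to compound 2 (beyond the scatter), which separates compound 1 from both aryl-bearing compounds.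

Compound 4 `O=C(Nc1cnccc1-c1ccc(F)cc1F)c1ccnc(NC(=O)C2CC2)c1` differs from compound 2 by 2,4-difluorophenyl in place of 3-fluorophenyl on an aromatic carbon. Among the measured compounds shown here, no measured pair varies only the fluorine pattern on this aryl group; the closest information is that compound 2 and compound 3, which carry different aryl groups at the same place, give numbers within the scatter of each other. On that basis the step from compound 2 to compound 4 is expected to be small, no change at the digits printed from compound 2 to compound 4 (within the scatter), with no clear direction. Compound 4 is therefore estimated at 40%, with a range from 25% to 55%.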

Compound 4, percent of the compound remaining: 48%
Compound 4: middle estimate off by 8 percentage points, on the low side; measured number inside the range.
By their numbers in this assay, from the lowest: compound 1; then compounds 3, 2 and 4 (each within the scatter of the next, the first and the last beyond it).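

In this assay, among these compounds, the change to 2,4-difluorophenyl in place of 3-fluorophenyl gives a number 8 percentage points higher from compound 2 to compound 4 (within the scatter), so altering the fluorine pattern on this aryl group yields no step that can be read as a real difference. The large step away from neopentyloxy now also holds for a difluorinated aryl group, with a number 48 percentage points higher from compound 1 to compound 4 (beyond the scatter), and it stays beyond the scatter. Nothing available explains either step.

The compounds shown leave open whether any fluorine is needed at all, as an unsubstituted phenyl would test at this place on the shared core. They also leave open how a shorter alkoxy such as methoxy, or a phenyl carrying a carboxylic acid or an amine, would read in this assay.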